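Replacing Isopropyl on the Amide Nitrogen of Compound 1

This account rests on a few compounds, and the source may have more. Where it says the series, first, only, none or still open, it means among the compounds named here.

Compound 1 `Cc1ccc(OCC(=O)N(Cc2cccs2)C(C)C)cc1`: 70 nM
Compound 2 `CCN(Cc1cccs1)C(=O)COc1ccc(C#N)cc1`: 1990 nM

In an assay on HEK293 cells for agonist activity at transient receptor potential cation channel subfamily M member 8 (Homo sapiens), read by fluorescence and calcium flux, with a stated time of 15 min (a lower number here means that less compound is needed, a higher number that more compound is needed for the effect), compound 1 gives 70 nM, the lowest of the two numbers. Compound 2 gives 1990 nM, a gap from compound 1 that lies beyond the scatter. Compound 3 `Cc1ccc(OCC(=O)N(Cc2cccs2)c2ccon2)cc1` has not yet been measured in this assay. It differs from compound 1 in one place: 1,2-oxazol-3-yl in place of isopropyl on an amide-type nitrogen. Going by the values given here, no step between measured compounds covers a change of this kind, so the direction rests on little. A moderate rise in the number, past the scatter, is expected from a 3.6-fold higher number from compound 1 to compound 3 (0.55 log units; beyond the scatter). The estimate for compound 3 in this assay is 250 nM, expected within 50 nM to 1500 nM.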

Compound 3, half-maximal effective concentration: 2 nM
Compound 3: the middle estimate sits 130-fold (2.10 log units) above what was measured; measured number below the stated range.
By their numbers in this assay, from the lowest: compound 3; then compound 1; then compound 2.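

On the amide-type nitrogen of the core of compound 1, isopropyl is not the limit for a low number: in this assay, 1,2-oxazol-3-yl in its place gives a 35-fold lower number from compound 1 to compound 3 (1.54 log units; beyond the scatter), a large step beyond the scatter. This position therefore accepts an aromatic five-membered ring carrying two hetero atoms, and the number falls with it. Nothing measured here explains this step.

Going by these compounds, whether the ring itself or its hetero atoms matter remains open. On these data alone, a plain phenyl ring on this nitrogen would separate the two, and what it would give is unknown.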